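The source may hold more compounds than are shown below. What is called first, only, known or untested is meant among the compounds shown, and "the series" means these compounds.

Measured compounds:
- compound 1 `COc1cc(Cl)cc(-c2nn(-c3cccc(NC(=O)Nc4cc(C(F)(F)F)cc(C(F)(F)F)c4)c3)cc2-c2ccncc2)c1`, which in a functional assay on BT-549 cells (Homo sapiens) for inhibition, read by sulforhodamine B assay, with a stated time of 48 h, tested at 100 uM (on this read-out higher numbers stand for a weaker effect at the one concentration tested and lower numbers for a stronger effect), gives -80%
- compound 2 `COc1cc(Cl)cc(-c2nn(-c3cccc(NC(=O)Nc4ccc(Cl)c(Cl)c4)c3)cc2-c2ccncc2)c1`, which in this assay gives -15%

Compound 2 stands highest of the two numbers, so it shows the weaker effect; compound 1 lies far lower, beyond the scatter. Compound 3 `COc1cc(Cl)cc(-c2nn(-c3cccc(NC(=O)Nc4cccc(C(F)(F)F)c4)c3)cc2-c2ccncc2)c1` differs from compound 2 in one place: 3-(trifluoromethyl)phenyl in place of 3,4-dichlorophenyl on an amide-type nitrogen. Going by the values given here, no directly comparable step between measured compounds is available. Since compound 1, carrying two trifluoromethyl groups on that ring, gives -80%, the expected step of a number 30 percentage points lower from compound 2 to compound 3 (beyond the scatter) is toward a stronger effect, beyond the scatter. Compound 3 is therefore estimated at -45%, with a range from -80% to -5%.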

Compound 3, a percentage reported as activity, at one concentration (the size of the read-out at that concentration, not a potency): -48%
Beside the measured number, compound 3's estimate is 3 percentage points above it; the range from low to high includes it.
By their numbers in this assay, from the lowest: compound 1; then compound 3; then compound 2.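

Within this assay, the ring on the amide-type nitrogen is a sensitive place: 3-(trifluoromethyl)phenyl in place of 3,4-dichlorophenyl gives a number 33 percentage points lower from compound 2 to compound 3 (beyond the scatter) and so a stronger effect. Hydrogen in place of one trifluoromethyl on an aromatic carbon gives a number 32 percentage points higher from compound 1 to compound 3 (beyond the scatter) and so a weaker effect, which means the second trifluoromethyl group counts. No measurement here accounts for either step.

As far as these compounds go, whether a nitrile or a carboxylic acid in place of trifluoromethyl on this ring would keep the effect remains open.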